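The source may hold more compounds than are shown below. What is called first, only, known or untested is meant among the compounds shown, and "the series" means these compounds.

In a functional assay on BaF3 cells (Mus musculus) for antiproliferative activity, with a stated time of 48 h (a lower number here means a stronger inhibitor, a higher number a weaker inhibitor), compound 1 (`CC(=O)N1CCN([C@H]2C[C@@H](n3cc(-c4ccc(Cl)c(O)c4)c4c(N)ncnc43)C2)CC1`) gives 3700 nM. Compound 2 (`CC(=O)N1CCN([C@H]2C[C@@H](n3cc(-c4ccccc4O)c4c(N)ncnc43)C2)CC1`) gives > 10000 nM, which is a limit of the assay and not a number. Compound 3 (`COc1cc(-c2cn([C@H]3C[C@@H](N4CCN(C(C)=O)CC4)C3)c3ncnc(N)c23)ccc1Cl`) has 4-chloro-3-methoxyphenyl in place of 2-hydroxyphenyl on an aromatic carbon. For the measured compounds named here, the one measured step that bears on this is an at least 2.7-fold higher number from compound 1 to compound 2 (0.43 log units; beyond the scatter), where 2-hydroxyphenyl replaced 4-chloro-3-hydroxyphenyl. Leaving 2-hydroxyphenyl is therefore expected to recover a modest part of that loss in this assay, towards a lower number. The expected change is an at least 2.2-fold lower number from compound 2 to compound 3 (0.34 log units; beyond the scatter). For compound 3 the estimated value is 4500 nM, with a range of 1500 nM to 10000 nM.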

Compound 3, half-maximal inhibitory concentration: > 10000 nM
Compound 3 ended at the assay's limit (the forecaster's own chance of this, stated with the estimate: 30%); at least 2.2-fold (0.34 log units) between middle value and limit.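

Putting methyl on the oxygen of the 4-chloro-3-hydroxyphenyl group, which removes its hydrogen-bond donor, gives an at least 2.7-fold higher number from compound 1 to compound 3 (0.43 log units; beyond the scatter) in this assay, so the free hydroxyl matters in this series even with the chlorine kept. Compound 3 gives > 10000 nM, which is a limit of the assay and not a number. The step from compound 2 to compound 3 cannot be read, and only compound 1 has a measured number: the limit of > 10000 nM in this assay, at which 2 of the 3 values shown sit.

On these data alone, whether an amine or a carboxylic acid in place of that hydroxyl would keep the activity of compound 1 stays open. As far as these compounds go, how far compound 2 and compound 3 lie beyond the limit also stays open.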